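This account rests on a few compounds, and the source may have more. Where it says the series, first, only, none or still open, it means among the compounds named here.

Compound 1, `Nc1ccc(-c2cc(=O)c3c(N)c(F)cc(F)c3o2)cc1F`: 40 nM
Compound 2, `Cc1c(F)c(N)c2c(=O)cc(-c3ccc(N)c(F)c3)oc2c1F`: 13 nM
Compound 3, `Nc1ccc(-c2cc(=O)c3c(N)c(F)c(O)c(F)c3o2)cc1F`: a limit of the assay, > 10000 nM, as noted in the limit of > 10000 nM in this assay, at which 1 of the 3 values shown sits.

In a functional assay on MCF7 cells (Homo sapiens) for cytotoxicity, read by neutral red uptake, with a stated time of 3 days (a lower number here means a stronger inhibitor, a higher number a weaker inhibitor), compound 1 stands at the highest of the two numbers; the nearest is compound 2, reached by a 3.1-fold lower number from compound 1 to compound 2 (0.49 log units; beyond the scatter). Compound 4, `COc1c(F)c(N)c2c(=O)cc(-c3ccc(N)c(F)c3)oc2c1F`, differs from compound 1 by methoxy in place of hydrogen on an aromatic carbon. Among the measured compounds shown here, two measured steps bear on this change. One is a 3.1-fold lower number from compound 1 to compound 2 (0.49 log units; beyond the scatter). The other is an at least 250-fold higher number from compound 1 to compound 3 (2.39 log units; beyond the scatter), and from compound 2 the same position gives an at least 760-fold higher number from compound 2 to compound 3 (2.88 log units; beyond the scatter). Methoxy is neither methyl nor hydroxy, so the expected step lies between these two outcomes, most likely a modest rise in the number. Compound 4 is therefore estimated at 80 nM, within 12 nM to 800 nM, which would mean a 2.0-fold higher number from compound 1 to compound 4 (0.30 log units; within the scatter).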

Compound 4, half-maximal inhibitory concentration: 100 nM
Estimate against measurement, compound 4: 1.3-fold (0.10 log units) below; the range from low to high includes it.
By their numbers in this assay, from the lowest: compound 2; then compound 1; then compound 4. At a limit, above all of these: compound 3.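

At this position, ortho to two fluoro groups, methoxy carries only a modest penalty in this assay (a 2.5-fold higher number from compound 1 to compound 4 (0.40 log units; beyond the scatter)) and falls behind methyl (a 7.7-fold higher number from compound 2 to compound 4 (0.89 log units; beyond the scatter)). The large loss seen with hydroxy does not persist once methyl replaces the hydrogen on that oxygen (an at least 100-fold lower number from compound 3 to compound 4 (2.00 log units; beyond the scatter)). The figure for compound 3 is a limit of the assay: the limit of > 10000 nM in this assay, at which 1 of the 4 values shown sits.

From the compounds shown here alone, what remains open is how an ethoxy group or a longer chain on the same oxygen would behave, and whether an amine at this position would resemble methoxy or hydroxy.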